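Phenyl in Place of Methyl: an Expected Cytotoxicity Value

The source may report more compounds than this note shows. Statements on the series, on what has been measured and on what is new or still open speak of the compounds shown alone.

Four compounds share one core. Compound 1 `COc1ccc(-c2cs/c(=N/NC(=O)CSc3nnnn3-c3ccccc3)n2-c2ccccc2)cc1` and compound 2 `N#Cc1ccc(-c2cs/c(=N/NC(=O)CSc3ncccn3)n2-c2ccccc2)cc1` were taken into a functional assay on C6 cells (Rattus norvegicus) for cytotoxicity, read by MTT assay, with a stated time of 24 h; on this read-out higher numbers stand for weaker inhibition and lower numbers for stronger inhibition: in this assay compound 1 gives "not determined" (no result reported) and compound 2 gives "not determined" (no result reported), so no result was reported for either. For the measured compounds named here, compound 3 `Cn1nnnc1SCC(=O)N/N=c1/scc(-c2ccc(C#N)cc2)n1-c1ccccc1` is the only one with a number: in this assay compound 3 gives 23.3 ug/mL, and it therefore stands alone, with nothing beside it to compare against.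

Compound 4 `N#Cc1ccc(-c2cs/c(=N/NC(=O)CSc3nnnn3-c3ccccc3)n2-c2ccccc2)cc1` has not yet been measured in this assay. It differs from compound 3 in one place: phenyl in place of methyl on an aromatic nitrogen. Cut one bond further out, the same difference reads 1-methyl-1H-tetrazol-5-yl to 1-phenyl-1H-tetrazol-5-yl.

Going by the values given here, no pair of measured compounds shows what such a change does here, so the expectation rests on compound 3 alone. The expected step, a 1.2-fold lower number from compound 3 to compound 4 (0.07 log units; within the scatter), is estimated to stay within the scatter, with no clear direction either way. Compound 4 is accordingly expected to give about 20 ug/mL in this assay, with a likely range from 7 ug/mL to 60 ug/mL.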

Compound 4, half-maximal inhibitory concentration: > 200 ug/mL
Compound 4: a limit, no number; the forecaster's own chance of this, stated with the estimate: 15%; middle value at least 10-fold (1.00 log units) from the limit.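

For the compounds shown here, this pair gives the first comparison, and it shows that the group on this aromatic nitrogen is not a neutral choice. In this assay, phenyl in place of methyl gives an at least 8.5-fold higher number from compound 3 to compound 4 (0.93 log units; beyond the scatter), and on this read-out a higher number means weaker inhibition. For compound 4 the result is a limit of the assay and not a number: the limit of > 200 ug/mL in this assay, at which 1 of the 4 values shown sits.

From the compounds shown here alone, the true size of the step therefore stays open, and a single pair cannot show which feature of phenyl matters. Going by these compounds, it also remains open whether an ethyl or a benzyl group on this nitrogen would stay close to compound 3 or move towards compound 4.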